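A fluorine added to the core of compound 1

The compounds below may be only part of what the source reports. "The series", "measured", "known", "first", "only" and "open" are said of these compounds alone.

Compound 1 `Cc1cccc(N2CCN(CCCNc3nc(NCc4ccco4)c4ccccc4n3)CC2)c1C` is the reference here. In a functional assay on DU-145 cells (Homo sapiens) for cytotoxicity, read by MTT assay, with a stated time of 2 days (a lower number here means a stronger inhibitor, a higher number a weaker inhibitor), compound 1 gives 930 nM, the lowest of the two numbers measured. Compound 3 `c1coc(CNc2nc(NCCCN3CCCC3)nc3ccccc23)c1` gives 35300 nM in this assay, a gap from compound 1 that lies beyond the usual scatter. For compound 2 `CCCCNc1nc(NCc2ccco2)c2cccc(F)c2n1` this assay has "not determined" (no result reported).

Compound 4 `Cc1cccc(N2CCN(CCCNc3nc(NCc4ccco4)c4cc(F)ccc4n3)CC2)c1C` differs from compound 1 in one place: fluoro in place of hydrogen on an aromatic carbon. Going by the values given here, no step of this kind stands among the measured compounds, so the expected change is small. Compound 4 is expected to give about 800 nM in this assay, between 300 nM and 2500 nM. The expected step from compound 1 to compound 4 is a 1.2-fold lower number from compound 1 to compound 4 (0.07 log units; within the scatter), within the scatter.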

Compound 4, half-maximal inhibitory concentration: 2660 nM
For compound 4 the middle estimate is 3.3-fold (0.52 log units) below the measured one; measured number outside the range, above it.
By their numbers in this assay, from the lowest: compound 1; then compound 4; then compound 3.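

In this assay the change gives a 2.9-fold higher number from compound 1 to compound 4 (0.46 log units; beyond the scatter) and so shows that this aromatic carbon of the core is not indifferent to a single fluoro group, with the number moving towards a weaker inhibitor. Going by these compounds alone, the earlier compounds offered no step at all, so this is the first reading of a change on the core alone. Nothing measured here gives a reason for the shift.

On these data alone, whether a chlorine atom or a methoxy group on the same carbon would move the number the same way stays open. So does whether fluoro on the other carbons of this ring would behave alike.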